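This account rests on a few compounds, and the source may have more. Where it says the series, first, only, none or still open, it means among the compounds named here.

Measured so far:
Compound 1, `COC(=O)c1cccc2c(C(=O)c3ccccc3)cc(C(=O)c3ccc(C(F)(F)F)cc3)c-2c1`, gives 27%.
Compound 2, `O=Cc1cc(-c2ccccc2)c2ccc(C(=O)O)ccc1-2`, gives 21.5%.
Compound 3, `O=C(Oc1ccc2ccc(Cl)ccc1-2)c1cccs1`, gives 33.2%.

All three were tested in an assay on cells for displacement of a labelled ligand from Orexin receptor type 2 (Homo sapiens), read by scintillation counting, with stated times of 10 min and 90 min, tested at 10 uM; on this read-out higher numbers stand for more inhibition at the one concentration tested (going by the name of the read-out) and lower numbers for less inhibition. Compound 3 holds the highest of the three numbers, but only its gap to compound 2 lies beyond the usual scatter of repeated measurements; its gap to compound 1 lies within that scatter, so compound 3 and compound 1 cannot be told apart on this read-out.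

Compound 3 is an ester whose carbonyl carbon carries a thiophen-2-yl group. Compound 4, `COC(=O)CCC(=O)Oc1ccc2ccc(Cl)ccc1-2`, has not yet been measured. It differs from compound 3 in one place: 2-(methoxycarbonyl)ethyl in place of thiophen-2-yl on a carbonyl carbon. The aromatic ring is removed, and a short chain that ends in a second ester takes its place.

Among the compounds with values here, no measured pair in this set isolates such an exchange, so there is no step to lean on, and the three measured numbers sit close together. In this assay compound 4 is therefore expected to stay near compound 3. The step of a number 9.2 percentage points lower from compound 3 to compound 4 (within the scatter) is estimated to be no more than a modest drop, within the scatter. The estimate for compound 4 is 24%, expected to fall between 8% and 40%.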

Compound 4, a percentage reported as inhibition, at one concentration (the size of the read-out at that concentration, not a potency): 24.3%
The estimate for compound 4 lay 0.3 percentage points below the measured number; the measured number falls inside the stated range.
By their numbers in this assay, from the lowest: compounds 2, 4, 1 and 3 (each within the scatter of the next, the first and the last beyond it).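

Within the data shown here, this is the first pair in the set that differs in only one place, and in this assay the exchange gives a number 8.9 percentage points lower from compound 3 to compound 4 (within the scatter) and so leaves the two compounds indistinguishable. On this carbonyl carbon, then, thiophen-2-yl, with its five-membered aromatic ring, and 2-(methoxycarbonyl)ethyl, which has no ring and carries a second ester, cannot be separated by this read-out, so the pair gives no sign that an aromatic ring is needed at this place for the inhibition seen at the one concentration tested. No available evidence accounts for this result.

The compounds shown leave open whether a carboxylic acid or an amine at the end of the chain, or a longer chain, would give a number beyond the usual scatter from that of compound 3. They also leave open whether a phenyl ring in place of thiophen-2-yl would separate from either compound, and how the two compare in potency, since a percentage at one concentration does not measure potency.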